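Phenyl for isopropyl on the amide chain

The source may hold more compounds than are shown below. What is called first, only, known or untested is meant among the compounds shown, and "the series" means these compounds.

In a functional assay on A549 cells (Homo sapiens) for cytotoxicity, read by MTT assay, with a stated time of 48 h (on this read-out lower numbers stand for stronger inhibition and higher numbers for weaker inhibition), compound 1 (`NC(=O)CC[C@H](NS(=O)(=O)c1ccc([N+](=O)[O-])cc1)C(=O)O`) gives > 500000 nM, which is a limit of the assay and not a number. Going by the values given here, compound 2 (`CCNC(=O)CC[C@H](NS(=O)(=O)c1ccc([N+](=O)[O-])cc1)C(=O)O`) gives 221000 nM, the only true number so far. Compound 3 (`CC(C)CNC(=O)CC[C@H](NS(=O)(=O)c1ccc([N+](=O)[O-])cc1)C(=O)O`) gives > 500000 nM, again only a limit. It therefore sits at the limit of > 500000 nM in this assay, at which 2 of the 3 values shown sit.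

Compound 4 (`O=C(CC[C@H](NS(=O)(=O)c1ccc([N+](=O)[O-])cc1)C(=O)O)NCc1ccccc1`) differs from compound 3 by phenyl in place of isopropyl on a saturated chain carbon bound to an amide-type nitrogen.

Among the compounds with values here, three measured steps concern this nitrogen: ethyl gave an at least 2.2-fold lower number from compound 1 to compound 2 (0.35 log units; beyond the scatter), extension to isobutyl gave an at least 2.2-fold higher number from compound 2 to compound 3 (0.35 log units; beyond the scatter), and the remaining pair shows a step that the two limits leave unreadable from compound 1 to compound 3. None of them involves a ring, so the direction is weakly supported. A modest move to a lower number in this assay is expected, given the reading of compound 2 at 221000 nM. There is also a real chance that compound 4 remains at the limit of the assay.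

The expected change is an at least 1.6-fold lower number from compound 3 to compound 4 (0.22 log units; that floor lies within the scatter). For compound 4 the estimated value is 300000 nM, with an expected range of 120000 nM to 500000 nM.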

Compound 4, half-maximal inhibitory concentration: 343000 nM
Compound 4: middle estimate off by 1.1-fold (0.06 log units), on the low side, within the range that was stated.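

In this assay the benzyl amide gives a true reading where the isobutyl amide gave only a limit, with an at least 1.4-fold lower number from compound 3 to compound 4 (0.16 log units; that floor lies within the scatter) as a floor and no more. The same holds against the unsubstituted amide, with an at least 1.4-fold lower number from compound 1 to compound 4 (0.16 log units; that floor lies within the scatter) again only a floor, while the ethyl and benzyl amides cannot be told apart, with a 1.6-fold higher number from compound 2 to compound 4 (0.19 log units; within the scatter) as their step. This position therefore takes a six-membered aromatic ring and keeps a readable value, but compound 1 and compound 3 remain limits of the assay, so no step from them has a true size: the limit of > 500000 nM in this assay, at which 2 of the 4 values shown sit.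

From the compounds shown here alone, whether any group here moves the reading clear of compound 2 and compound 4 stays open. A phenethyl group in place of benzyl, or a methoxy group on the phenyl, would test how far the ring can be changed.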